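A Limit-Bound Pair and One Open Step

The source may report more compounds than this note shows. Statements on the series, on what has been measured and on what is new or still open speak of the compounds shown alone.

For the measured compounds named here, only two compounds have been read so far in a functional assay on HCT-116 cells (Homo sapiens) for inhibition, read by MTT assay, with a stated time of 48 h; a higher number here means a weaker inhibitor, a lower number a stronger inhibitor. Compound 1 `COc1ccc(-n2c(SCC(=O)c3ccc(OC)c(O)c3)nnc2-c2cc(OC)c(OC)c(OC)c2)cc1` returns a limit rather than a number, > 60000 nM. Compound 2 `COc1cc(-c2nnc(SCc3ccc(F)cc3)n2-c2ccc(N(C)C)cc2)cc(OC)c1OC` also returns only a limit, > 60000 nM. Compound 2 therefore has no exact position on the scale, and the record so far is the limit of > 60000 nM in this assay, at which 2 of the 2 values shown sit. Going by the values given here, no measured step exists to show how far a structural change can move the read-out.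

Compound 3 `COc1ccc(C(=O)CSc2nnc(-c3cc(OC)c(OC)c(OC)c3)n2-c2ccc(N(C)C)cc2)cc1O` departs from compound 2 with (3-hydroxy-4-methoxyphenyl)carbonyl in place of 4-fluorophenyl on a saturated chain carbon bound to a sulfur. In other words, 4-fluorobenzyl gives way to ((3-hydroxy-4-methoxyphenyl)carbonyl)methyl.

The expected change is an at least 10-fold lower number from compound 2 to compound 3 (1.00 log units; beyond the scatter) in this assay, toward a stronger inhibitor, and this is a judgement from the structural change alone. The expectation starts from compound 2 and its limit of > 60000 nM, so a further limit remains a real possibility. For compound 3 the estimated value is 6000 nM, with an expected range from 400 nM to 60000 nM.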

Compound 3, half-maximal inhibitory concentration: > 100000 nM
Compound 3: no number, only a limit; the forecaster's own chance of this, stated with the estimate: 35%; middle value at least 16-fold (1.22 log units) from the limit.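

In this assay, compound 3 returns only a limit, > 100000 nM. For the compounds shown here, compound 1 and compound 2 also return only limits, so no step to compound 3 can be read from either of them. The compounds shown leave open what number any of them would have and how far a single structural change can move the read-out.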